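Bromo on the terminal phenyl of the urea series

A few compounds are considered here, and "the series" means these few. Any claim that something is new, unique, unknown or untested is made for them only; others in the source may bear on it.

Measured so far in a functional assay on MKN-45 cells (Homo sapiens) for cytotoxicity, read by MTT assay, with a stated time of 72 h; a lower number here means a stronger inhibitor, a higher number a weaker inhibitor:
compound 1, `COc1cc2c(Oc3ccc(NC(=O)N/N=C/c4cccs4)cc3F)ccnc2cc1OCCCN1CCCCC1`, 740 nM
compound 2, `COc1cc2c(Oc3ccc(NC(=S)N/N=C/c4ccccc4)cc3F)ccnc2cc1OCCCN1CCCCC1`, 710 nM
compound 3, `COc1cc2c(Oc3ccc(/C=N/NC(=O)Nc4ccccc4)cc3F)ccnc2cc1OCCCN1CCCCC1`, 180 nM

Compound 3 gives the lowest number of the three, and both of its steps lie beyond the scatter: a 4.1-fold lower number from compound 1 to compound 3 (0.61 log units; beyond the scatter) and a 3.9-fold lower number from compound 2 to compound 3 (0.60 log units; beyond the scatter). Compounds 1 and 2 stand within the scatter of each other, a 1.0-fold lower number from compound 1 to compound 2 (0.02 log units; within the scatter), so no order is read between them. Compound 3 is therefore the strongest inhibitor of the set in this assay.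

Compound 4 is `COc1cc2c(Oc3ccc(/C=N/NC(=O)Nc4ccc(Br)cc4)cc3F)ccnc2cc1OCCCN1CCCCC1`. It differs from compound 3 in one place: bromo in place of hydrogen on an aromatic carbon.

Going by the values given here, none of the measured steps bears on this change. Among the compounds with values here, the steps between compounds 1, 2 and 3 all concern the group attached at the hydrazone end or the sulfur-for-oxygen exchange; no measured pair differs by a substituent on the six-membered aromatic ring of carbon only. There is thus no basis in these data for expecting a step beyond the scatter in either direction, and the expectation for compound 4 is a number close to that of compound 3, no change at the digits printed from compound 3 to compound 4 (within the scatter), with a wide range to cover an untested kind of change. Compound 4 is estimated at 180 nM, between 60 nM and 550 nM.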

Compound 4, half-maximal inhibitory concentration: 60 nM
Compound 4: the middle estimate sits 3.0-fold (0.48 log units) above what was measured; measured number inside the range.
By their numbers in this assay, from the lowest: compound 4; then compound 3; then compounds 2 and 1 (each within the scatter of the next).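

In this assay, going by these compounds alone, the terminal phenyl of the urea series turns out to be a place where a single substituent counts: a 3.0-fold lower number from compound 3 to compound 4 (0.48 log units; beyond the scatter) is the only measured change on this ring, whereas the earlier steps concerned the group at the hydrazone end or the sulfur-for-oxygen exchange. One bromine atom on an aromatic carbon, para to a large group, is therefore enough to carry the number beyond the scatter, and in the direction of a stronger inhibitor, so this position is tolerant of substitution, at least for bromo. Nothing measured on these compounds bears on the reason for this step, and the size of the gain stays unexplained.

Open, as far as these compounds go, is whether the gain belongs to bromo itself or to substitution here in general, a question that chloro, methoxy or a dimethylamino group on the same carbon would settle. Also open, from the compounds shown here alone, is whether bromo on another carbon of this phenyl ring, or on the phenyl of compound 2, would give a step of similar size.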